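Swapping the aryl group on the carbonyl carbon

The compounds below may be only part of what the source reports. "The series", "measured", "known", "first", "only" and "open" are said of these compounds alone.

In a functional assay on HCT-116 cells (Homo sapiens) for inhibition, read by sulforhodamine B assay, with a stated time of 3 days (on this read-out lower numbers stand for stronger inhibition and higher numbers for weaker inhibition), compound 2 (`CN1CCN(c2cccc(N/C=C3\C(=O)Nc4ccc(NC(=O)c5c(Cl)cccc5Cl)cc43)c2)CC1`) gives 2280 nM and compound 1 (`CN1CCN(c2cccc(N/C=C3\C(=O)Nc4ccc(NC(=O)c5c(F)cccc5F)cc43)c2)CC1`) gives 2150 nM, so the two values lie within the scatter of each other. Compound 3 (`CN1CCC(C(=O)Nc2ccc3c(c2)/C(=C/Nc2cccc(N4CCN(C)CC4)c2)C(=O)N3)CC1`) has 1-methylpiperidin-4-yl in place of 2,6-dichlorophenyl on a carbonyl carbon. Among the compounds with values here, the only measured step that bears on this change is a 1.1-fold higher number from compound 1 to compound 2 (0.03 log units; within the scatter), which exchanges 2,6-difluorophenyl for 2,6-dichlorophenyl at the same place. Within the data shown here, no measured compound carries a non-aromatic ring there, so that step gives no direction for this assay, and no step beyond the scatter is expected, though with low confidence. The expected change is a 1.1-fold higher number from compound 2 to compound 3 (0.04 log units; within the scatter). For compound 3 the estimated value is 2500 nM, with an expected range of 700 nM to 9000 nM.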

Compound 3, half-maximal inhibitory concentration: 4670 nM
Estimate against measurement, compound 3: 1.9-fold (0.27 log units) below; low and high end bracket the measured number.
By their numbers in this assay, from the lowest: compounds 1 and 2 (each within the scatter of the next); then compound 3.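

Replacing 2,6-dichlorophenyl with 1-methylpiperidin-4-yl on the carbonyl carbon in this assay gives a 2.0-fold higher number from compound 2 to compound 3 (0.31 log units; beyond the scatter) and replacing 2,6-difluorophenyl with the same group gives a 2.2-fold higher number from compound 1 to compound 3 (0.34 log units; beyond the scatter) so this place does respond to a change of group, modestly and towards weaker inhibition. The exchange of halogens on the aromatic ring showed no such response, and compounds 1 and 2 both stand on the stronger side of compound 3. No available evidence accounts for the shift.

The compounds shown do not separate the loss of the aromatic ring from the entry of the ring nitrogen. A cyclohexyl group on the same carbonyl carbon would bear on that, and an unsubstituted phenyl group would show whether the two halogens matter at all.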